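This account rests on a few compounds, and the source may have more. Where it says the series, first, only, none or still open, it means among the compounds named here.

Measured in a functional assay on the whole organism (strain Wistar) for inhibition, with Rattus norvegicus as the target, read by paw edema, with a stated time of 4 h, at a dose of 10 mg/kg by the intraperitoneal route (on this read-out higher numbers stand for more inhibition at the one dose given (going by the name of the read-out) and lower numbers for less inhibition), so far:

Compound 1 `O=C(N/N=C/c1ccc(Cl)cc1)c1cccnc1Nc1cccc(C(F)(F)F)c1`, 43.7%.
Compound 2 `O=C(N/N=C/c1cccc(O)c1)c1cccnc1Nc1cccc(C(F)(F)F)c1`, 35.8%.
Compound 3 `COc1ccc(/C=N/NC(=O)c2cccnc2Nc2cccc(C(F)(F)F)c2)cc1`, 14%.

Compound 3 stands lowest of the three; from compound 1 the step is a number 29.7 percentage points lower from compound 1 to compound 3 (beyond the scatter) and from compound 2 it is a number 21.8 percentage points lower from compound 2 to compound 3 (beyond the scatter), both beyond the scatter, while compound 1 against compound 2 gives a number 7.9 percentage points lower from compound 1 to compound 2 (within the scatter), within the scatter.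

Compound 4 `CN(C)c1ccc(/C=N/NC(=O)c2cccnc2Nc2cccc(C(F)(F)F)c2)cc1` is not yet measured. Against compound 3 the change is dimethylamino in place of methoxy on an aromatic carbon. Going by the values given here, the steps that touch the same aromatic carbon, from compound 1 to compound 3 and from compound 2 to compound 3, both lowered the number by a modest amount, but neither involves dimethylamino, so no measured step speaks directly for this change. For compound 4 a step of a number 4 percentage points higher from compound 3 to compound 4 (within the scatter) is therefore expected, not clearly beyond the scatter in either direction. Compound 4 is estimated at 18%, with a range from 5% to 35%.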

Compound 4, a percentage reported as inhibition, in the whole organism at one dose (the size of the read-out at that dose, not a potency): 28.2%
For compound 4 the middle estimate is 10.2 percentage points below the measured one; the measured number falls inside the stated range.
By their numbers in this assay, from the lowest: compound 3; then compounds 4, 2 and 1 (each within the scatter of the next, the first and the last beyond it).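

In this assay, going by these compounds alone, dimethylamino in place of methoxy gives a number 14.2 percentage points higher from compound 3 to compound 4 (beyond the scatter) and so shows that the number at this aromatic carbon, para to a large group, can also rise, where the earlier steps to methoxy only lowered it. Chloro stays ahead of dimethylamino, with a number 15.5 percentage points lower from compound 1 to compound 4 (beyond the scatter) here, while a number 7.6 percentage points lower from compound 2 to compound 4 (within the scatter) leaves the 3-hydroxyphenyl and 4-(dimethylamino)phenyl compounds unseparated. No measured evidence accounts for these differences.

Open, from the compounds shown here alone, is whether a primary amine, a carboxylic acid or a longer alkoxy chain at this carbon would stay near the methoxy compound or near the chloro compound.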